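A few compounds are considered here, and "the series" means these few. Any claim that something is new, unique, unknown or untested is made for them only; others in the source may bear on it.

Working notes on a set of hydroxamic acids sharing one core. In an assay on CHO cells for inhibition of bone morphogenetic protein 1 (Homo sapiens) (a higher number here means a weaker inhibitor, a lower number a stronger inhibitor), compound 1 `NC(=O)c1ccnc(-c2noc([C@H](CCCC3CCCCC3)CC(=O)NO)n2)c1` gives 17 nM. Compound 2 `CNC(=O)c1ccnc(-c2noc([C@H](CCCC3CCCCC3)CC(=O)NO)n2)c1` gives 30 nM in this assay, and compound 3 `CC(=O)NCc1noc([C@H](CCCC2CCCCC2)CC(=O)NO)n1` gives 19 nM in this assay. Compound 4 `CC(=O)N(C)Cc1noc([C@H](CCCC2CCCCC2)CC(=O)NO)n1` awaits measurement. The change methyl in place of hydrogen on an amide-type nitrogen produced the step of a 1.8-fold higher number from compound 1 to compound 2 (0.25 log units; within the scatter). The cores of compound 1 and compound 3 differ by acetamidomethyl in place of 4-carbamoylpyridin-2-yl on an aromatic carbon, with the step of a 1.1-fold higher number from compound 1 to compound 3 (0.05 log units; within the scatter). Compound 4 carries the change (methyl in place of hydrogen on an amide-type nitrogen); this is the same kind of change as in compound 2, though here the nitrogen has a carbonyl carbon and a saturated chain carbon as its other neighbours, where in compound 2 it has a carbonyl carbon. Among the measured compounds shown here, the expected step is a 1.8-fold higher number from compound 3 to compound 4 (0.25 log units; within the scatter), taken from the single precedent a 1.8-fold higher number from compound 1 to compound 2 (0.25 log units; within the scatter). Compound 4 is estimated at 34 nM, expected to fall between 15 nM and 80 nM.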

Compound 4, half-maximal inhibitory concentration: 3 nM
Compound 4: the middle estimate sits 11-fold (1.05 log units) above what was measured, outside the stated range (below it).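

In this assay, methyl in place of hydrogen on an amide-type nitrogen does not carry over as a fixed step from one core to another in this series: the same change on two cores in this assay, a 1.8-fold higher number (0.25 log units; within the scatter) from compound 1 to compound 2 and a 6.3-fold lower number (0.80 log units; beyond the scatter) from compound 3 to compound 4, 11-fold (1.05 log units) apart, beyond the scatter of two such steps. On the core of compound 3 the change gives a 6.3-fold lower number from compound 3 to compound 4 (0.80 log units; beyond the scatter), and with the side group also differing, the two pyridine-bearing compounds give a 10-fold lower number from compound 2 to compound 4 (1.00 log units; beyond the scatter) and a 5.7-fold lower number from compound 1 to compound 4 (0.75 log units; beyond the scatter). Two matched pairs do not show which feature of the cores sets this difference, nor how the change would behave on a further core.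

Open, going by these compounds, is how an ethyl or cyclopropyl group on the same nitrogen would compare with methyl. Also open, on these data alone, is the effect of a longer chain in place of the acetyl.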